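Swapping the aryl group on the hydrazone of compound 2

A few compounds are considered here, and "the series" means these few. Any claim that something is new, unique, unknown or untested is made for them only; others in the source may bear on it.

Two compounds share one core and differ only in the aryl group on a carbon with a double bond to nitrogen. In an ADME assay on WI-38 cells (Homo sapiens) for cytotoxicity, read by MTT assay, with a stated time of 72 h (on this read-out lower numbers stand for stronger inhibition and higher numbers for weaker inhibition), compound 1 `CN(C)CCn1cnnc1-c1cc(Oc2ccc(NC(=O)N/N=C/c3c(Cl)cccc3Cl)cc2F)ccn1` gives 3320 nM, and compound 2 `CN(C)CCn1cnnc1-c1cc(Oc2ccc(NC(=O)N/N=C/c3ccc(F)cc3Cl)cc2F)ccn1` gives 2090 nM, the lowest of these two numbers; the step of a 1.6-fold lower number from compound 1 to compound 2 (0.20 log units; within the scatter) stays within the scatter. Compound 3 `Cc1cc(/C=N/NC(=O)Nc2ccc(Oc3ccnc(-c4nncn4CCN(C)C)c3)c(F)c2)cc(C)c1O` carries the change (4-hydroxy-3,5-dimethylphenyl in place of 2-chloro-4-fluorophenyl on a carbon with a double bond to nitrogen). Within the data shown here, the only measured step, from compound 1 to compound 2, also swapped this aryl group and changed little, so no step beyond the scatter is expected in this assay, giving a 1.2-fold higher number from compound 2 to compound 3 (0.08 log units; within the scatter). Compound 3 is therefore estimated at 2500 nM, ranging from 1000 nM to 7000 nM.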

Compound 3, half-maximal inhibitory concentration: 3610 nM
Beside the measured number, compound 3's estimate is 1.4-fold (0.16 log units) below it; low and high end bracket the measured number.
By their numbers in this assay, from the lowest: compounds 2, 1 and 3 (each within the scatter of the next).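

In this assay, 4-hydroxy-3,5-dimethylphenyl at this position gives a 1.7-fold higher number from compound 2 to compound 3 (0.24 log units; within the scatter) and a 1.1-fold higher number from compound 1 to compound 3 (0.04 log units; within the scatter). This position on a carbon with a double bond to nitrogen therefore now holds an aryl group with a hydrogen-bond donor and acceptor, which the two halogenated groups lack, with no step beyond the scatter. No measurement here offers a reason for this result.

Going by these compounds, whether an aryl group carrying an amine or a carboxylic acid would move the number remains open. So does the effect of a longer alkyl chain in place of the aryl ring.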